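This account rests on a few compounds, and the source may have more. Where it says the series, first, only, none or still open, it means among the compounds named here.

Compound 1 `O=C1Nc2ccc(S(=O)(=O)N3CCOCC3)cc2/C1=N/c1ccc(Br)cc1` carries a shared core to which a 4-bromophenyl is attached through a double-bonded nitrogen. In a functional assay on HepG2 cells (Homo sapiens) for cytotoxicity, read by sulforhodamine B assay, with a stated time of 24 h (a lower number here means a stronger inhibitor, a higher number a weaker inhibitor), compound 1 gives 11900 nM. Two related compounds have also been measured: compound 2 `O=C1Nc2ccc(S(=O)(=O)N3CCOCC3)cc2/C1=N/c1cccc(C(F)(F)F)c1` gives 14300 nM, and compound 3 `CC(=O)c1cccc(/N=C2\C(=O)Nc3ccc(S(=O)(=O)N4CCOCC4)cc32)c1` gives 28600 nM. Compound 1 has the lowest number of the three, but the step of a 1.2-fold higher number from compound 1 to compound 2 (0.08 log units; within the scatter) is within the scatter, so compounds 1 and 2 cannot be told apart, while the step of a 2.4-fold higher number from compound 1 to compound 3 (0.38 log units; beyond the scatter) is a modest one beyond the scatter. Between compounds 2 and 3 the step of a 2.0-fold higher number from compound 2 to compound 3 (0.30 log units; within the scatter) stays within the scatter.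

Compound 4 `O=C1Nc2ccc(S(=O)(=O)N3CCOCC3)cc2/C1=N/c1ccc(Cl)cc1` has not yet been measured. It differs from compound 1 by chloro in place of bromo on an aromatic carbon. Going by the values given here, none of the measured steps exchanges one halogen for another; both steps from compound 1 replace the whole 4-bromophenyl with a differently substituted ring, and even the larger of them, a 2.4-fold higher number from compound 1 to compound 3 (0.38 log units; beyond the scatter), is only modest. The change to compound 4 touches a single heavy atom, so in this assay no step beyond the scatter is expected. Compound 4 is therefore estimated at 13000 nM, with a range from 7000 nM to 25000 nM, a step of a 1.1-fold higher number from compound 1 to compound 4 (0.04 log units; within the scatter) that is expected to stay within the scatter.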

Compound 4, half-maximal inhibitory concentration: 11800 nM
Beside the measured number, compound 4's estimate is 1.1-fold (0.04 log units) above it; measured number inside the range.
By their numbers in this assay, from the lowest: compounds 4, 1, 2 and 3 (each within the scatter of the next, the first and the last beyond it).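

In this assay, going by these compounds alone, putting chloro in place of bromo on this aromatic carbon, para to a large group, gives a 1.0-fold lower number from compound 1 to compound 4 (0.00 log units; within the scatter) and so leaves the number effectively unchanged, which the earlier compounds could not show, since their steps exchanged a whole substituted ring rather than one halogen for another. Compound 4 also behaves like compound 1 against the other two rings: the step of a 1.2-fold lower number from compound 2 to compound 4 (0.08 log units; within the scatter) stays within the scatter, whereas the step of a 2.4-fold lower number from compound 3 to compound 4 (0.38 log units; beyond the scatter) is a modest one beyond it. No measured information is available to explain why bromo and chloro give such similar numbers here.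

On these data alone, it remains open whether this position responds to any change at all, and a fluoro, a methoxy, an amine or a carboxylic acid on the same aromatic carbon would test that more widely than a swap between two halogens. The shared core is also the same in all four compounds, so nothing here tells how much its parts contribute to the numbers.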